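A Chloro-Methyl Ring Follows Three Dimethyl Amides

The source may report more compounds than this note shows. Statements on the series, on what has been measured and on what is new or still open speak of the compounds shown alone.

Compound 3 `Cc1ccc(C(=O)NC(CCN(C)C)c2ccc(Cl)cc2)c(C)c1` is one of three amides on a shared core that differ only in the group on a carbonyl carbon. In an assay on NIH3T3 cells with Urotensin-2 receptor (Homo sapiens) as the target (a higher number here means a larger maximal response, a lower number a smaller maximal response), compound 3 gives 147%, the lowest of the three numbers. Compound 1 `Cc1cccc(C(=O)NC(CCN(C)C)c2ccc(Cl)cc2)c1C` gives 159% in this assay, and compound 2 `Cc1ccc(C)c(C(=O)NC(CCN(C)C)c2ccc(Cl)cc2)c1` gives 164%. The two steps that lead to compound 3 are a number 12 percentage points lower from compound 1 to compound 3 (beyond the scatter) and a number 17 percentage points lower from compound 2 to compound 3 (beyond the scatter), both modest but beyond the scatter, while the step of a number 5 percentage points higher from compound 1 to compound 2 (within the scatter) stays within it. Compound 4 `Cc1cccc(Cl)c1C(=O)NC(CCN(C)C)c1ccc(Cl)cc1` has not yet been measured. 2-chloro-6-methylphenyl in place of 2,4-dimethylphenyl on a carbonyl carbon Of the measured steps, the two into compound 3 bear on this change: going from 2,3-dimethylphenyl or 2,5-dimethylphenyl to 2,4-dimethylphenyl lowered the number, so leaving 2,4-dimethylphenyl again may recover part of that loss. Going by the values given here, no measured compound carries a 2-chloro-6-methylphenyl, so the size of the step is uncertain and a range on either side of the three known numbers is reasonable. Compound 4 is therefore expected to show a modest rise, a number 5 percentage points higher from compound 3 to compound 4 (within the scatter), in this assay. The estimate for compound 4 in this assay is 152%, with a range from 125% to 178%.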

Compound 4, largest response reached (reported as efficacy), in percent of the reference or control that the assay uses: 105%
The estimate for compound 4 lay 47 percentage points above the measured number; measured number outside the range, below it.
By their numbers in this assay, from the lowest: compound 4; then compound 3; then compounds 1 and 2 (each within the scatter of the next).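

In this assay, going by these compounds alone, this position proves far more sensitive than the three dimethylphenyl amides showed: 2-chloro-6-methylphenyl in place of 2,4-dimethylphenyl gives a number 42 percentage points lower from compound 3 to compound 4 (beyond the scatter) and the same group gives a number 59 percentage points lower from compound 2 to compound 4 (beyond the scatter) and also a number 54 percentage points lower from compound 1 to compound 4 (beyond the scatter) with each of these steps large, whereas the earlier steps were modest or within the scatter. Compound 4 therefore stands lowest of the four, even though the leaving and entering groups have the same heavy-atom count, a single six-membered aromatic ring and no hydrogen-bond donors or acceptors, so none of these counted features tracks the change in the number. No evidence is available that accounts for this drop.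

Compound 4 differs from the dimethylphenyl amides both in carrying chlorine and in the arrangement of its two groups, and the four compounds cannot show which of these goes with the lower number. A 2,6-dimethylphenyl on the same carbonyl carbon would separate the two, and a 2,4-dichlorophenyl would show how chlorine reads in an arrangement already seen with methyl groups.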